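Swapping an aromatic ring for cyclohexyl

The compounds below may be only part of what the source reports. "The series", "measured", "known", "first", "only" and "open" are said of these compounds alone.

Measured in a functional assay on HeLa cells (Homo sapiens) for cytotoxicity, read by MTT assay, with a stated time of 72 h; a higher number here means a weaker inhibitor, a lower number a stronger inhibitor:
- compound 1 `O=C(Nc1nnc(-c2cccc(O)c2O)s1)c1ccccc1`: 21800 nM
- compound 2 `Cc1ccc(C(=O)Nc2nnc(-c3cccc(O)c3O)s2)cc1`: 13400 nM

Among the measured compounds shown here, only one step has been measured so far: a 1.6-fold lower number from compound 1 to compound 2 (0.21 log units; within the scatter). This step, methyl in place of hydrogen on an aromatic carbon, lies within the scatter. Compound 2 therefore stands level with compound 1 on these numbers, and the two cannot be ranked.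

Compound 3 `O=C(Nc1nnc(-c2cccc(O)c2O)s1)C1CCCCC1` differs from compound 2 in one place: cyclohexyl in place of 4-methylphenyl on a carbonyl carbon. In words, cyclohexyl in place of 4-methylphenyl on a carbonyl carbon, so an aromatic ring gives way to a non-aromatic one. The measured step bears on this only loosely, since it changed a single group on the aromatic ring and kept the ring itself. For the measured compounds named here, no compound measured so far carries a non-aromatic ring at this place, so the data give no direction for the change. In this assay, no step beyond the scatter is expected, although the uncertainty is wide. The expected change is a 1.2-fold higher number from compound 2 to compound 3 (0.08 log units; within the scatter). For compound 3, the estimated value is 16000 nM, with an expected range of 7000 nM to 40000 nM.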

Compound 3, half-maximal inhibitory concentration: 91600 nM
The estimate for compound 3 lay 5.7-fold (0.76 log units) below the measured number, outside the stated range (above it).
By their numbers in this assay, from the lowest: compounds 2 and 1 (each within the scatter of the next); then compound 3.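

In this assay, replacing 4-methylphenyl with cyclohexyl on the carbonyl carbon gives a 6.8-fold higher number from compound 2 to compound 3 (0.83 log units; beyond the scatter), and replacing plain phenyl with cyclohexyl at the same place gives a 4.2-fold higher number from compound 1 to compound 3 (0.62 log units; beyond the scatter). Adding a methyl to the aromatic ring had left the number within the scatter, whereas replacing the ring itself moves it beyond the scatter, and both steps point the same way: among these three compounds, those with an aromatic ring at this place are the stronger inhibitors, and none goes against this. Both kinds of ring are six-membered, carry no hydrogen-bond donors or acceptors and have no net charge, yet no measurement here explains the difference between them.

Cyclohexyl is the only non-aromatic ring shown, so it remains open whether the higher number belongs to non-aromatic rings in general or to this one group. Going by these compounds, it is also open whether a pyridine ring, which brings nitrogen into the aromatic ring, or an open butyl chain at this place would sit nearer compound 1 and compound 2 or nearer compound 3.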